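Taking the methyl off compound 2

The compounds below may be only part of what the source reports. "The series", "measured", "known", "first", "only" and "open" are said of these compounds alone.

Of the compounds shown here, two have values so far. In a functional assay on A549 cells (Homo sapiens) for inhibition, read by MTT assay, with a stated time of 48 h (on this read-out higher numbers stand for weaker inhibition and lower numbers for stronger inhibition), compound 1 `CCc1ccc(-c2nc3ccccn3c2Sc2ccccc2)cc1` gives 56200 nM. Compound 2 `Cc1ccc2nc(-c3ccc(Cl)cc3)c(Sc3ccccc3)n2c1` gives 71500 nM, which lies within the usual scatter of the value for compound 1, so the two cannot be told apart on these numbers. Both values mark weak inhibition on this read-out.

Compound 3 `Clc1ccc(-c2nc3ccccn3c2Sc2ccccc2)cc1` has not yet been measured. It differs from compound 2 by a single change hydrogen in place of methyl on an aromatic carbon of a six-membered aromatic ring with 1 nitrogen, part of a fused or bridged system of two rings. For the measured compounds named here, no measured pair differs in only one place, so the data hold no direct precedent for the size of such a step in this assay. The expectation therefore rests on the two values in hand, and no step beyond the scatter is expected, in either direction. The estimated 1.2-fold lower number from compound 2 to compound 3 (0.08 log units; within the scatter) stays within the scatter. For compound 3 the expected value is 60000 nM, with an estimated range of 25000 nM to 130000 nM.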

Compound 3, half-maximal inhibitory concentration: 22000 nM
Estimate against measurement, compound 3: 2.7-fold (0.44 log units) above; the measured number lies below the stated range.
By their numbers in this assay, from the lowest: compound 3; then compounds 1 and 2 (each within the scatter of the next).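

In this assay the first single-place comparison shows that this aromatic carbon, two atoms from the ring nitrogen, is not indifferent to its substituent: hydrogen in place of methyl gives a 3.3-fold lower number from compound 2 to compound 3 (0.51 log units; beyond the scatter), a modest change but one that lies beyond the scatter. The second pair shows that a single change at another aromatic carbon also registers, with chloro in place of ethyl giving a 2.6-fold lower number from compound 1 to compound 3 (0.41 log units; beyond the scatter), so both steps converge on compound 3 as the compound with the lowest number of the three. Nothing measured here explains either step, and both describe only what happens around this one core.

The compounds shown leave open whether the methyl step would recur on a core carrying ethyl rather than chloro, since each change is seen only once and in one setting. They also leave open how this ring carbon would respond to a methoxy group, an amine or a carboxylic acid, and whether a longer chain or a bromo group in place of the chloro would move the number further in either direction.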